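From thiophen-2-yl to 1,3-thiazol-5-yl on the carbonyl carbon

The source may hold more compounds than are shown below. What is called first, only, known or untested is meant among the compounds shown, and "the series" means these compounds.

In a physicochemical assay for solubility, read by HPLC, with a stated time of 24 h (on this read-out lower numbers stand for lower solubility and higher numbers for higher solubility), compound 1 (`CC(C)(C)c1[nH]cnc1/C=c1\[nH]c(=O)/c(=C/c2cccc(C(=O)N3CCC3)c2)[nH]c1=O`) gives 4.23 ug/mL as a measured number. Compound 2 (`CC(C)(C)c1[nH]cnc1/C=c1\[nH]c(=O)/c(=C/c2cccc(C(=O)N3CCCCC3)c2)[nH]c1=O`) reads < 0.1 ug/mL and this is a limit of the assay. Compound 3 (`CC(C)(C)c1[nH]cnc1/C=c1\[nH]c(=O)/c(=C/c2cccc(C(=O)c3cccs3)c2)[nH]c1=O`) reads < 0.1 ug/mL and this too is a limit. Compound 3 thus shares with compound 2 the limit of < 0.1 ug/mL in this assay, at which 2 of the 3 values shown sit, and has no number of its own.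

Two measured steps at the carbonyl carbon are large: an at least 42-fold lower number from compound 1 to compound 2 (1.62 log units; beyond the scatter) and an at least 42-fold lower number from compound 1 to compound 3 (1.62 log units; beyond the scatter) in the same direction. Alongside them stands a step that the two limits leave unreadable from compound 2 to compound 3 and so the piperidin-1-yl and thiophen-2-yl groups cannot be ranked.

The next change, to compound 4 (`CC(C)(C)c1[nH]cnc1/C=c1\[nH]c(=O)/c(=C/c2cccc(C(=O)c3cncs3)c2)[nH]c1=O`), puts 1,3-thiazol-5-yl in place of thiophen-2-yl on a carbonyl carbon. Among the measured compounds shown here, no measured step exchanges one five-membered aromatic ring for another, and both large steps start from azetidin-1-yl, so neither sets a size for this change. Compound 3 offers only the limit < 0.1 ug/mL as a starting point in this assay and a small upward step is the most that can be expected, with another limit reading quite possible. The estimated step is an at least 2.0-fold higher number from compound 3 to compound 4 (0.30 log units; that floor lies within the scatter) and it carries wide uncertainty. The expected value for compound 4 is 0.2 ug/mL with an estimated range of 0.05 ug/mL to 1.5 ug/mL in this series.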

Compound 4, solubility: < 0.1 ug/mL
Compound 4: a limit, no number; the forecaster's own chance of this, stated with the estimate: 50%; middle value at least 2.0-fold (0.30 log units) away from the limit.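

In this assay compound 4 reads < 0.1 ug/mL, and this is a limit of the assay, not a number. Changing thiophen-2-yl to 1,3-thiazol-5-yl on the carbonyl carbon adds a hetero atom and a hydrogen-bond acceptor, yet the reading stays at the limit shared by compound 2 and compound 3, so none of the steps among these three compounds can be read. The one readable new step is an at least 42-fold lower number from compound 1 to compound 4 (1.62 log units; beyond the scatter), which makes three large steps, all starting from azetidin-1-yl, and shows that an aromatic ring with 2 hetero atoms on the carbonyl carbon also gives no number, leaving compound 1 as the only compound with a measured value: the limit of < 0.1 ug/mL in this assay, at which 3 of the 4 values shown sit.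

As far as these compounds go, whether piperidin-1-yl, thiophen-2-yl and 1,3-thiazol-5-yl differ from one another under the limit stays open, since only a limit stands for each. Also open, from the compounds shown here alone, is whether the measurable reading belongs to azetidin-1-yl alone or extends to other amides on the carbonyl carbon, such as pyrrolidin-1-yl, morpholin-4-yl or a piperazine carrying a free amine.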